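The compounds below may be only part of what the source reports. "The series", "measured", "known", "first", "only" and "open" are said of these compounds alone.

Measured in a functional assay on KB cells (Homo sapiens) for cytotoxicity, read by MTT assay, with a stated time of 72 h; on this read-out higher numbers stand for an effect only at larger amounts of compound and lower numbers for an effect already at smaller amounts:
- compound 1 `CCc1cccc2c(OC)c(-c3occ(C)c3C(=O)OC)ccc12`: 1.7 ug/mL
- compound 2 `CCOC(=O)c1c(C)coc1-c1ccc2c(CC)cccc2c1OC`: 2.2 ug/mL
- compound 3 `CCc1cccc2c(OC)c(-c3occ(C)c3C(=O)NC)ccc12`: > 10 ug/mL (a limit)

Compound 3 gives > 10 ug/mL, which is a limit of the assay and not a number. Within the data shown here, no measured compound gives a number on its far side.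

Compound 4 `CCc1cccc2c(OC)c(-c3occ(C)c3C(=O)On3nnc4ccccc43)ccc12` differs from compound 3 by a group of 10 heavy atoms (6 carbon, 3 nitrogen, 1 oxygen; one five-membered aromatic ring with 3 hetero atoms, one six-membered aromatic ring of carbon only) in place of a group of 2 heavy atoms (1 carbon, 1 nitrogen; no ring), on a carbonyl carbon. The change removes the methylamino group from the carbonyl carbon. Among the measured compounds shown here, two measured steps concern that group: an at least 5.8-fold higher number from compound 1 to compound 3 (0.76 log units; beyond the scatter) and an at least 4.5-fold higher number from compound 2 to compound 3 (0.65 log units; beyond the scatter). Both introduce methylamino on a carbonyl carbon and both lie beyond the scatter. The step of a 1.3-fold higher number from compound 1 to compound 2 (0.11 log units; within the scatter) lies within it.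

Read in reverse, these steps suggest a lower number once methylamino leaves, of similar or greater size. For the measured compounds named here, the entering group has no measured counterpart, so the expectation stays loose. The expected move in this assay is an at least 3.3-fold lower number from compound 3 to compound 4 (0.52 log units; beyond the scatter). For compound 4 the estimated value is 3 ug/mL, with an expected range of 0.8 ug/mL to 10 ug/mL.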

Compound 4, concentration for half-maximal effect: > 10 ug/mL
Compound 4 was reported as a limit; the forecaster's own chance of this, stated with the estimate: 20%; at least 3.3-fold (0.52 log units) between middle value and limit.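

In this assay compound 4 gives > 10 ug/mL, which is a limit of the assay and not a number. Removing methylamino from the carbonyl carbon is therefore not enough on its own to return to the values of the methyl and ethyl esters, since the ring-bearing group of compound 4 gives an at least 5.8-fold higher number from compound 1 to compound 4 (0.76 log units; beyond the scatter) and an at least 4.5-fold higher number from compound 2 to compound 4 (0.65 log units; beyond the scatter). The step between compound 3 and compound 4 cannot be read, and the two compounds share one limit: the limit of > 10 ug/mL in this assay, at which 2 of the 4 values shown sit.

Any real difference between the methylamino compound and the ring-bearing compound stays hidden at that limit. From the compounds shown here alone, it also remains open whether a carboxylic acid or a propyl ester at this carbonyl carbon would give a number close to those of the methyl and ethyl esters or would reach the same limit.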